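Changing the Aryl Link on a Shared Core

This account rests on a few compounds, and the source may have more. Where it says the series, first, only, none or still open, it means among the compounds named here.

Compound 1, `COc1ccc(Sc2nc3cc(N)cc(N)c3nc2-c2ccccc2)cc1`: in a functional assay on MDA-MB-231 cells (Homo sapiens) for inhibition, read by sulforhodamine B assay, with a stated time of 48 h (a higher number here means a weaker inhibitor of growth, a lower number a stronger inhibitor of growth), compound 1 gives < 100000 nM, which is a limit of the assay rather than a number.
Compound 2, `Nc1cc(N)c2nc(-c3ccccc3)c(Sc3ccc(Cl)c(Cl)c3)nc2c1`: in this assay compound 2 gives 53700 nM.

Among the measured compounds shown here, compound 2 holds the only number recorded in this assay; the other value recorded is a limit. For the measured compounds named here, the one step between measured compounds, a step that the limit leaves unreadable from compound 1 to compound 2, cannot be sized, because the limit of < 100000 nM in this assay, at which 1 of the 2 values shown sits, hides where compound 1 truly sits.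

Compound 3, `Nc1cc(N)c2nc(-c3ccccc3)c(Oc3ccc(F)cc3)nc2c1`, differs from compound 2 in one place: 4-fluorophenoxy in place of (3,4-dichlorophenyl)sulfanyl on an aromatic carbon. Going by the values given here, no measured step shares this change. Among the compounds with values here, the only measured step, a step that the limit leaves unreadable from compound 1 to compound 2, is unreadable, so it offers neither a direction nor a size for the move from a sulfur-linked dichlorophenyl group to an oxygen-linked fluorophenyl group. With nothing to lean on, compound 3 is expected to land near compound 2, and the step of a 1.1-fold higher number from compound 2 to compound 3 (0.05 log units; within the scatter) is taken as no change beyond the scatter, with a wide spread to reflect the uncertainty. The estimated value for compound 3 is 60000 nM, within a range from 15000 nM to 250000 nM.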

Compound 3, concentration for total growth inhibition: 28800 nM
Estimate against measurement, compound 3: 2.1-fold (0.32 log units) above, within the range that was stated.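

Among the compounds shown here, this is the first step at this position that can be read. In this assay, putting 4-fluorophenoxy in place of (3,4-dichlorophenyl)sulfanyl on this aromatic carbon gives a 1.9-fold lower number from compound 2 to compound 3 (0.27 log units; within the scatter), so an exchange of the linking atom and the halogens on the outer ring together leaves the two compounds indistinguishable in this measurement. For this pair, then, the aromatic carbon next to the ring nitrogen can carry either of these two aryl groups, with sulfur or oxygen as the link, without a difference beyond the scatter. The step from compound 1 to compound 3 cannot be read, because compound 1 is recorded only as a limit and not as a number: the limit of < 100000 nM in this assay, at which 1 of the 3 values shown sits.

The link atom and the halogens on the outer ring change together in this single step, and the compounds shown do not separate the two. Also open, going by these compounds, is how this position would respond to a group of another kind on the same aromatic carbon, such as an amine, a carboxylic acid or a longer alkyl chain.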